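Trifluoromethyl on the saturated ring: from compound 3 to compound 4

The compounds below may be only part of what the source reports. "The series", "measured", "known", "first", "only" and "open" are said of these compounds alone.

Compound 3 `COc1ccc(F)c(-c2ccc(Cc3ccc(N4CCC[C@H]4CC(=O)O)cc3)c(C)c2)c1` gives 1900 nM in a functional assay on cells for agonist activity at Free fatty acid receptor 1 (Mus musculus), read by FLIPR and calcium flux, with a stated time of 100 s (on this read-out higher numbers stand for an effect only at larger amounts of compound and lower numbers for an effect already at smaller amounts), the highest of the two numbers obtained in the series; compound 2 `Cc1ccccc1Cc1ccc(N2C[C@@H](C(F)(F)F)C[C@H]2CC(=O)O)cc1` gives 710 nM. Compound 1 `Cc1ccccc1Cc1ccc(N2CCC[C@H]2CC(=O)O)cc1` gives only a limit, > 33000 nM. The step to compound 4 `COc1ccc(F)c(-c2ccc(Cc3ccc(N4C[C@@H](C(F)(F)F)C[C@H]4CC(=O)O)cc3)c(C)c2)c1` is trifluoromethyl in place of hydrogen on a saturated ring carbon. The same change has been measured once: an at least 46-fold lower number from compound 1 to compound 2 (1.66 log units; beyond the scatter), a lower bound only because of the limit of > 33000 nM in this assay, at which 1 of the 3 values shown sits. The other measured step, an at least 17-fold lower number from compound 1 to compound 3 (1.23 log units; beyond the scatter), adds the large aryl group that compound 4 already carries. A large downward step in this assay is therefore expected, a 48-fold lower number from compound 3 to compound 4 (1.68 log units; beyond the scatter). Compound 4 is expected to give 40 nM, with a range from 10 nM to 160 nM.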

Compound 4, half-maximal effective concentration: 2400 nM
The estimate for compound 4 lay 60-fold (1.78 log units) below the measured number; measured number above the stated range.
By their numbers in this assay, from the lowest: compound 2; then compounds 3 and 4 (each within the scatter of the next). At a limit, above all of these: compound 1.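

The gain from trifluoromethyl at this saturated ring carbon does not carry over between cores, as a 1.3-fold higher number from compound 3 to compound 4 (0.10 log units; within the scatter) shows on the core that bears the 2-fluoro-5-methoxyphenyl group: the same change on two cores in this assay, an at least 46-fold lower number (1.66 log units; beyond the scatter) from compound 1 to compound 2 and a 1.3-fold higher number (0.10 log units; within the scatter) from compound 3 to compound 4, at least 58-fold (1.76 log units) apart, beyond the scatter of two such steps. Likewise, a 3.4-fold higher number from compound 2 to compound 4 (0.53 log units; beyond the scatter) shows that the aryl group brings no gain once trifluoromethyl is present: the same change on two cores in this assay, an at least 17-fold lower number (1.23 log units; beyond the scatter) from compound 1 to compound 3 and a 3.4-fold higher number (0.53 log units; beyond the scatter) from compound 2 to compound 4, at least 58-fold (1.76 log units) apart, beyond the scatter of two such steps. The two changes are therefore not additive in this pair of cores. From the compounds shown here alone, whether a methyl or a hydroxyl at this ring carbon would behave the same way on both cores stays open.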